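Compound 3 to Compound 4: A Methyl Changes Place

This account rests on a few compounds, and the source may have more. Where it says the series, first, only, none or still open, it means among the compounds named here.

Three compounds were measured in a functional assay on the whole organism (strain albino) with Mus musculus as the target, at a dose of 100 mg/kg by the intraperitoneal route; on this read-out lower numbers stand for less inhibition and higher numbers for more inhibition at the one dose given (going by the name of the read-out):

Compound 1 `Cc1ccc(NC(=O)Nn2c(-c3ccccc3)nc3ccccc3c2=O)cc1`: 54%
Compound 2 `CCc1ccc(NC(=O)Nn2c(-c3ccccc3)nc3ccccc3c2=O)cc1`: 61%
Compound 3 `Cc1cccc(NC(=O)Nn2c(-c3ccccc3)nc3ccccc3c2=O)c1`: 59%

All three share one core and differ only in the group carried on an amide-type nitrogen whose other neighbour is a carbonyl carbon. The steps among them are small: a number 7 percentage points higher from compound 1 to compound 2 (within the scatter), a number 5 percentage points higher from compound 1 to compound 3 (within the scatter) and a number 2 percentage points lower from compound 2 to compound 3 (within the scatter), every one of them within the scatter. Compound 3 therefore stands second highest of three numbers that cannot be told apart, nearest to compound 2 and furthest from compound 1.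

Compound 4 `Cc1ccccc1NC(=O)Nn1c(-c2ccccc2)nc2ccccc2c1=O` has not yet been measured in this assay. It differs from compound 3 only as follows: 2-methylphenyl in place of 3-methylphenyl on an amide-type nitrogen. Within the data shown here, no measured step moves the methyl around the ring in this way; the closest comparison is compound 1 against compound 3, where a 4-methylphenyl and a 3-methylphenyl gave numbers within the scatter of each other. Among the measured compounds shown here, with every step so far within the scatter, and the group keeping its atoms and its ring, compound 4 is expected to stay close to compound 3, with a change of a number 2 percentage points lower from compound 3 to compound 4 (within the scatter) that does not exceed the scatter. Compound 4 is therefore estimated at 57%, within 44% to 69%.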

Compound 4, a percentage reported as inhibition, in the whole organism at one dose (the size of the read-out at that dose, not a potency): 59%
Estimate against measurement, compound 4: 2 percentage points below, within the range that was stated.
By their numbers in this assay, from the lowest: compounds 1, 3, 4 and 2 (each within the scatter of the next).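

In this assay the series now holds all three methylphenyl isomers on the amide-type nitrogen: 2-methylphenyl in place of 3-methylphenyl gave no change at the digits printed from compound 3 to compound 4 (within the scatter) and 2-methylphenyl in place of 4-methylphenyl gave a number 5 percentage points higher from compound 1 to compound 4 (within the scatter) so the 2-methylphenyl group extends to a further ring place what the comparison of the 3-methylphenyl and 4-methylphenyl compounds had suggested, and none of these three can be told apart. Exchanging 4-ethylphenyl for 2-methylphenyl gave a number 2 percentage points lower from compound 2 to compound 4 (within the scatter) and so, across these four compounds, neither the place of the methyl nor the ethyl group separates one number from another at this position. Nothing is available that would explain this flat result.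

From the compounds shown here alone, all four compounds carry only a methyl or an ethyl group on the phenyl ring, so it remains open whether an amine, a carboxylic acid, a methoxy group or a longer chain such as butyl on that ring would move the number beyond the scatter. Also open, going by these compounds, is what the bare phenyl group, or a cyclohexyl group in its place, would give on the same nitrogen, and how the compounds would compare at any other dose.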